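Swapping Methyl for Fluoro on Compound 2

The compounds below may be only part of what the source reports. "The series", "measured", "known", "first", "only" and "open" are said of these compounds alone.

Compound 1 `Cn1c2cnc1OCCCCCCCCCOc1ccccc1-2`: 69000 nM
Compound 2 `C=CCCCCOc1ccc(C)cc1-c1cnc(OCCC=C)n1C`: 59000 nM

In a functional assay on A549 cells (Homo sapiens) for inhibition, read by colorimetric assay and MTT assay, with a stated time of 72 h (a lower number here means a stronger inhibitor, a higher number a weaker inhibitor), compound 2 gives 59000 nM, and compound 1 gives 69000 nM. These two values lie within the usual scatter of each other, so compound 2 stands level with compound 1.

Compound 3 `C=CCCCCOc1ccc(F)cc1-c1cnc(OCCC=C)n1C` has fluoro in place of methyl on an aromatic carbon, para to a (hex-5-en-1-yl)oxy group (fluoro in place of methyl on an aromatic carbon). Among the measured compounds shown here, no measured pair shows this swap, so no shift beyond the scatter is expected, in either direction. The expected step is a 1.0-fold higher number from compound 2 to compound 3 (0.01 log units; within the scatter). Compound 3 is estimated at 60000 nM, with an expected range of 32000 nM to 110000 nM.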

Compound 3, half-maximal inhibitory concentration: 61000 nM
Beside the measured number, compound 3's estimate is 1.0-fold (0.01 log units) below it; the measured number falls inside the stated range.
By their numbers in this assay, from the lowest: compounds 2, 3 and 1 (each within the scatter of the next).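

In this assay, among the compounds shown here, the swap of methyl for fluoro on the aromatic carbon para to the (hex-5-en-1-yl)oxy group gives a 1.0-fold higher number from compound 2 to compound 3 (0.01 log units; within the scatter) and so provides the first measured pair at this position. In this pair, the two groups cannot be told apart by this read-out. No measurement here speaks to the reason for this result.

As far as these compounds go, whether an amine or a carboxylic acid at this position would give a number beyond the scatter of compound 2 stays open. So does the effect of a longer chain in place of the (hex-5-en-1-yl)oxy group.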